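From Hydroxy to Methoxy: An Expected Step

This account rests on a few compounds, and the source may have more. Where it says the series, first, only, none or still open, it means among the compounds named here.

Compound 1 `O=C(NCCCNc1cc(-c2cn(-c3ccccc3)nc2-c2cccc(O)c2)ccn1)Nc1ccc(F)cc1`: 6780 nM
Compound 2 `O=C(NCCCNc1cc(-c2cn(-c3ccccc3)nc2-c2cccc(O)c2)ccn1)Nc1cccc(C(F)(F)F)c1`: 5750 nM

Both values come from a functional assay on TK-10 cells (Homo sapiens) for antiproliferative activity, read by sulforhodamine B assay, with a stated time of 48 h; a higher number here means a weaker inhibitor, a lower number a stronger inhibitor. Of these two compounds, neither stands apart, and compound 1 sits level with compound 2 within the usual scatter. Within the data shown here, the one measured step is a 1.2-fold lower number from compound 1 to compound 2 (0.07 log units; within the scatter). It places 3-(trifluoromethyl)phenyl in place of 4-fluorophenyl on an amide-type nitrogen.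

Compound 3 `COc1cccc(-c2nn(-c3ccccc3)cc2-c2ccnc(NCCCNC(=O)Nc3ccc(F)cc3)c2)c1` has not yet been measured. It differs from compound 1 by methyl in place of hydrogen on an oxygen on an aromatic ring, which turns 3-hydroxyphenyl into 3-methoxyphenyl.

Among the measured compounds shown here, no measured step touches that oxygen. The step to compound 2 lies elsewhere in the structure, so it bears on this change only indirectly, showing that one change in the series left the number in this assay within the scatter. The data give no direction for the new change, so no shift beyond the scatter is expected, though the uncertainty is wide. The expected change is a 1.0-fold higher number from compound 1 to compound 3 (0.01 log units; within the scatter). For compound 3 the estimated value is 7000 nM, with an expected range from 2500 nM to 20000 nM.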

Compound 3, half-maximal inhibitory concentration: 21200 nM
The estimate for compound 3 lay 3.0-fold (0.48 log units) below the measured number; measured number outside the range, above it.
By their numbers in this assay, from the lowest: compounds 2 and 1 (each within the scatter of the next); then compound 3.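

Read in this assay the change from 3-hydroxyphenyl to 3-methoxyphenyl gives a 3.1-fold higher number from compound 1 to compound 3 (0.50 log units; beyond the scatter) and is the first single change in these compounds to move the number beyond the scatter, towards a weaker inhibitor. Among these compounds, the only earlier step altered the group on an amide-type nitrogen and left the number within the scatter, so it said nothing about this oxygen, which now proves to be a place where a methyl of one heavy atom in place of hydrogen is enough to register. Nothing available here accounts for the shift, and the size of the step is all that can be reported.

The compounds shown leave open whether the loss follows from removing the hydrogen on the oxygen or from adding the carbon, a question that an amine or a fluorine in place of the hydroxy group, or an ethoxy group in place of the methoxy group, could begin to separate. They also leave open whether the same change has a similar effect when the 3-(trifluoromethyl)phenyl group of compound 2 replaces the 4-fluorophenyl group.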